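This account rests on a few compounds, and the source may have more. Where it says the series, first, only, none or still open, it means among the compounds named here.

Compound 1 `COc1cc(C2CCN(C[C@@H](C)O)CC2)ccc1Nc1ncc2ccc(-c3ccccc3OC)n2n1`: in an in vitro ADME assay on microsomes from liver (Homo sapiens) for metabolic stability, using NADPH, with a stated time of 10 min, tested at 0.5 uM (on this read-out higher numbers stand for a longer-lived compound and lower numbers for a shorter-lived compound), compound 1 gives > 0.666 h.
Compound 2 `CNC(=O)CN1CCC(c2ccc(Nc3ncc4ccc(-c5ccccc5OC)n4n3)c(OC)c2)CC1`: in this assay compound 2 gives < 0.2 h.

Each of these values is a limit of the assay, not a number. Compound 2 stands at the limit of < 0.2 h in this assay, at which 1 of the 2 values shown sits, the shorter-lived end. Compound 1 stands at the limit of > 0.666 h in this assay, at which 1 of the 2 values shown sits. Compound 3 `COc1cc(C2CCN(CC(N)=O)CC2)ccc1Nc1ncc2ccc(-c3ccccc3OC)n2n1` differs from compound 2 by hydrogen in place of methyl on an amide-type nitrogen. Among the compounds with values here, the one measured step, an at least 3.3-fold lower number from compound 1 to compound 2 (0.52 log units; beyond the scatter), swapped the whole chain on the ring amine, so it bears only loosely on this smaller change at the amide. No step beyond the scatter is expected; the estimated step is a step that the limit leaves unreadable from compound 2 to compound 3. Compound 3 is therefore expected near 0.15 h, within 0.07 h to 0.35 h, and most likely again reported only as a limit.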

Compound 3, half-life: > 0.666 h
Compound 3: only a limit was reported; the forecaster's own chance of this, stated with the estimate: 70%; middle value at least 4.4-fold (0.64 log units) away from the limit.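

Hydrogen in place of methyl on the amide-type nitrogen gives an at least 3.3-fold higher number from compound 2 to compound 3 (0.52 log units; beyond the scatter) in this assay. The earlier step swapped the whole chain on the ring amine, whereas this one shows that the methyl alone is enough to separate two compounds at this amide. Compound 3 is reported only as a limit of the assay: the limit of > 0.666 h in this assay, at which 2 of the 3 values shown sit.

The step between compound 1 and compound 3 cannot be read, and neither can how far compound 3 lies past its limit. On these data alone, it also stays open how an ethyl group, or a second methyl, on that amide nitrogen would read.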